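This account rests on a few compounds, and the source may have more. Where it says the series, first, only, none or still open, it means among the compounds named here.

Compounds measured in an assay on isolated protein for inhibition of alpha-galactosidase A (Homo sapiens), read by fluorescence, tested at 100 uM; a lower number here means less inhibition, a higher number more inhibition at the concentration tested (going by the name of the read-out):
compound 1 `NC[C@@H]1NC[C@H](O)[C@H](O)[C@H]1O`: 45%
compound 2 `COc1ccc(Br)cc1/C=C/C(=O)NC[C@H]1NC[C@H](O)[C@@H](O)[C@H]1O`: 99%

Compound 1 stands lowest of these two numbers, and compound 2 sits well beyond the scatter above it. The new compound 3 `NC[C@H]1NC[C@H](O)[C@H](O)[C@H]1O` keeps every atom and bond of compound 1; (the two compounds have the same atoms and bonds and differ only in configuration as drawn: 1 of 4 stereo elements differ; a stereocentre at a saturated ring carbon is drawn S in compound 1 and R in compound 3). For the measured compounds named here, no pair of measured compounds here shows what such a change in configuration does in this assay, so any expectation rests on compound 1 alone. A change of configuration in this kind of compound is expected to lower inhibition, by an estimated step of a number 20 percentage points lower from compound 1 to compound 3 (beyond the scatter), with wide uncertainty in either direction. Compound 3 is therefore estimated at 25%, in a range from 2% to 60%.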

Compound 3, a percentage reported as inhibition, at one concentration (the size of the read-out at that concentration, not a potency): 19%
Compound 3: middle estimate off by 6 percentage points, on the high side; measured number inside the range.
By their numbers in this assay, from the lowest: compound 3; then compound 1; then compound 2.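

In this assay, switching one saturated ring carbon from S to R gives a number 26 percentage points lower from compound 1 to compound 3 (beyond the scatter). For the compounds shown here, no earlier pair isolated configuration, and this one shows that the spatial arrangement at this single stereocentre affects inhibition even with the atoms and bonds unchanged. The gap can be assigned to this stereocentre alone because of what the two structures show: the fact that compounds 1 and 3 differ only in the configuration as drawn

Still open, going by these compounds, is whether changing the other stereocentres has a similar effect. Also open, on these data alone, is whether this change matters as much when a carboxylic acid replaces the amine, or when a longer chain carries it.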